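The source may hold more compounds than are shown below. What is called first, only, known or untested is meant among the compounds shown, and "the series" means these compounds.

Measured so far:
- compound 1 `O=C(Nc1nc2ccc(F)cc2s1)c1cc(-c2ccc(F)cc2)n2nc(-c3ccccc3)cc2n1`: 35500 nM
- compound 2 `COc1ccc2nc(NC(=O)c3cc(-c4ccc(F)cc4)n4nc(-c5ccccc5)cc4n3)sc2c1`: 26300 nM

Both were tested in a functional assay on ACHN cells (Homo sapiens) for cytotoxicity, read by MTT assay, with a stated time of 48 h; on this read-out lower numbers stand for stronger inhibition and higher numbers for weaker inhibition. For the measured compounds named here, on these numbers compound 2 has the smaller of the two values, with compound 1 as its only neighbour, but the step of a 1.3-fold lower number from compound 1 to compound 2 (0.13 log units; within the scatter) is within the scatter, so the two compounds cannot really be separated.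

Compound 3 `Cc1cc2nc(NC(=O)c3cc(-c4ccc(F)cc4)n4nc(-c5ccccc5)cc4n3)sc2cc1C` has not yet been measured. It differs from compound 2 in one place: 5,6-dimethyl-1,3-benzothiazol-2-yl in place of 6-methoxy-1,3-benzothiazol-2-yl on an amide-type nitrogen. Going by the values given here, only one measured step touches this same part of the molecule, the group on the amide-type nitrogen, and that step, a 1.3-fold lower number from compound 1 to compound 2 (0.13 log units; within the scatter), shows no movement beyond the scatter. Among the compounds with values here, no measured pair puts the dimethyl pattern against the methoxy, so the change leading to compound 3 has no direct precedent, and nothing in the numbers points to a large move in either direction. The expectation for compound 3 in this assay is therefore a step of about a 1.1-fold lower number from compound 2 to compound 3 (0.02 log units; within the scatter), nothing beyond the scatter, with an estimated value of 25000 nM and a range from 10000 nM to 60000 nM.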

Compound 3, half-maximal inhibitory concentration: 33000 nM
Beside the measured number, compound 3's estimate is 1.3-fold (0.12 log units) below it; the measured number falls inside the stated range.
By their numbers in this assay, from the lowest: compounds 2, 3 and 1 (each within the scatter of the next).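

In this assay, putting 5,6-dimethyl-1,3-benzothiazol-2-yl in place of 6-methoxy-1,3-benzothiazol-2-yl on the amide-type nitrogen gives a 1.3-fold higher number from compound 2 to compound 3 (0.10 log units; within the scatter) and the same group in place of 6-fluoro-1,3-benzothiazol-2-yl gives a 1.1-fold lower number from compound 1 to compound 3 (0.03 log units; within the scatter) so neither step can be told apart from repeat-measurement noise. For the compounds shown here, compounds 1, 2 and 3 therefore cannot be separated, and this now holds for a benzothiazole with two methyl groups and no oxygen as well as for those carrying fluoro or methoxy, which is more than the single earlier step could show. No measurement here offers an explanation for this lack of separation.

As far as these compounds go, it remains open whether any group on this benzothiazole can move the number beyond the scatter, for example an amine or a carboxylic acid in place of the methyl, methoxy or fluoro groups. These three compounds also share everything else, so they cannot say whether the same insensitivity would hold with a different shared core, such as one bearing a longer chain.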